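The source may report more compounds than this note shows. Statements on the series, on what has been measured and on what is new or still open speak of the compounds shown alone.

Compound 1, `CC(C)n1ccnc1/N=C(\N)Nc1ccc(Cl)c(Cl)c1`, and compound 2, `N/C(=N\c1nccn1Cc1ccccc1)Nc1ccc(Cl)c(Cl)c1`, share a core and differ in one place: benzyl in place of isopropyl on an aromatic nitrogen. In an in vitro ADME assay on microsomes from liver (Mus musculus) for metabolic stability, read by LC-MS, tested at 1 uM (on this read-out higher numbers stand for a longer-lived compound and lower numbers for a shorter-lived compound), compound 1 gives 0.462 h. In this assay compound 2 gives 0.617 h. That step, a 1.3-fold higher number from compound 1 to compound 2 (0.13 log units; within the scatter), is too small to count as a real difference between the two.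

Compound 3, `CC(C)C(=O)N/C(=N/c1nccn1C(C)C)Nc1ccc(Cl)c(Cl)c1`, carries an added group on the shared core; how its core differs from that of compound 1 is not broken down here. For compound 3 this assay reports only a limit, > 1 h, which is the upper edge of what the assay reads, (the limit of > 1 h in this assay, at which 1 of the 3 values shown sits).

Compound 4, `CC(C)C(=O)N/C(=N/c1nccn1Cc1ccccc1)Nc1ccc(Cl)c(Cl)c1`, is not yet measured. It differs from compound 3 by benzyl in place of isopropyl on an aromatic nitrogen, the same change that was made from compound 1 to compound 2 and that gave a 1.3-fold higher number from compound 1 to compound 2 (0.13 log units; within the scatter). On that basis the step from compound 3 to compound 4 in this assay is expected to be about a step that the limit leaves unreadable from compound 3 to compound 4, again within the scatter. Compound 4 is therefore estimated to come out near the limit, at about 1.3 h.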

Compound 4, half-life: 0.183 h
Compound 4: the middle estimate sits 7.1-fold (0.85 log units) above what was measured; the measured number lies below the stated range.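

Benzyl in place of isopropyl on an aromatic nitrogen does not carry over unchanged from one core to the other in this assay: the same change on two cores in this assay, a 1.3-fold higher number (0.13 log units; within the scatter) from compound 1 to compound 2 and an at least 5.4-fold lower number (0.73 log units; beyond the scatter) from compound 3 to compound 4, at least 7.2-fold (0.86 log units) apart, beyond the scatter of two such steps. With the added group on the shared core, the change gives an at least 5.4-fold lower number from compound 3 to compound 4 (0.73 log units; beyond the scatter), so the small step seen without that group would have been a poor guide here. On these data alone, compound 3 has > 1 h, which is a limit of the assay and not a number, so the full size of the step on this core stays unknown, and one pair on each core shows no general rule for the series.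

The compounds shown leave open why the step differs between the cores, and whether the drop belongs to benzyl itself or would also appear with another group on that aromatic nitrogen, such as methyl or a longer chain. They also leave open how the same change would behave if an amine or a carboxylic acid stood in place of the added group.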